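This account rests on a few compounds, and the source may have more. Where it says the series, first, only, none or still open, it means among the compounds named here.

Working notes on the series. Compound 3 `CCOC(=O)C1=C(C)N(C)C(=O)NC1c1ccsc1` stands highest among the three numbers in hand: in an assay on membranes from HEK293 cells for displacement of a labelled ligand from adenosine receptor A2b (Homo sapiens), read by scintillation counting, with a stated time of 30 min, tested at 1 uM (on this read-out higher numbers stand for more inhibition at the one concentration tested (going by the name of the read-out) and lower numbers for less inhibition), compound 3 gives 53%. Among the compounds with values here, compound 2 `COC(=O)C1=C(C)N(C)C(=O)NC1c1ccsc1` in this assay gives 26%, and compound 1 `CCCOC(=O)C1=C(C)N(C)C(=O)NC1c1ccoc1` gives 2%; compound 1 differs from compound 3 in two places, so its value is only a second reference point and no single step joins them.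

Compound 4 `CCCOC(=O)C1=C(C)N(C)C(=O)NC1c1ccsc1` differs from compound 3 by methyl in place of hydrogen on a saturated chain carbon, two bonds along the chain from an oxygen next to a carbonyl group. Within the data shown here, the one measured step that bears on this is the extension of the same chain by one carbon nearer the oxygen, which went a number 27 percentage points higher from compound 2 to compound 3 (beyond the scatter). That step is of the same kind but one bond closer in, so it is taken as a loose guide only; the second extension is not expected to repeat its full size, and a small rise or no change beyond the scatter is the more cautious reading. On that basis the step from compound 3 is expected to be a number 5 percentage points higher from compound 3 to compound 4 (within the scatter). Compound 4 is accordingly estimated at 58%, with a range from 32% to 82%.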

Compound 4, a percentage reported as inhibition, at one concentration (the size of the read-out at that concentration, not a potency): 1%
For compound 4 the middle estimate is 57 percentage points above the measured one; measured number below the stated range.
By their numbers in this assay, from the lowest: compounds 4 and 1 (each within the scatter of the next); then compound 2; then compound 3.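

The ester chain does not respond in one direction: lengthening ethoxy to propoxy reverses the earlier gain, giving a number 52 percentage points lower from compound 3 to compound 4 (beyond the scatter), so among the methyl, ethyl and propyl esters carrying thiophen-3-yl, the ethyl ester of compound 3 stands highest. The propyl ester also falls under the methyl ester, with a number 25 percentage points lower from compound 2 to compound 4 (beyond the scatter), which places the loss beyond simply undoing the first extension. With the propyl ester in place, the ring change shows no separable difference, at a number 1 percentage points lower from compound 1 to compound 4 (within the scatter), so this pair gives no ranking of thiophen-3-yl against furan-3-yl.

Still open, going by these compounds, are whether a butyl or isopropyl ester would stay as low as the propyl ester and whether furan-3-yl would match thiophen-3-yl on the ethyl ester. No measurement in hand accounts for the sharp drop at this chain position.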